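From Nitrile to (4-Fluorophenyl)carbonyl on a Shared Core

A few compounds are considered here, and "the series" means these few. Any claim that something is new, unique, unknown or untested is made for them only; others in the source may bear on it.

Two measured compounds set the frame. Compound 1 `CCOC(=O)c1cc2c(-c3cccnc3)nn(-c3ccccc3)c2nc1-c1cccnc1` in a functional assay on HepG2 cells (Homo sapiens) for cytotoxicity, read by sulforhodamine B assay (a higher number here means a weaker inhibitor, a lower number a stronger inhibitor), gives 3.75 ug/mL. Compound 2 `N#Cc1cc2c(-c3cccnc3)nn(-c3ccccc3)c2[nH]c1=O` gives 3.3 ug/mL in this assay, and it stands at the low end of the two numbers, separated from compound 1 by a gap that falls within the usual scatter, so the two cannot be told apart. Among the measured compounds shown here, no step between them has been worked out, as they differ in more than one place.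

Compound 3 `O=C(c1ccc(F)cc1)c1cc2c(-c3cccnc3)nn(-c3ccccc3)c2[nH]c1=O` has not yet been measured. It departs from compound 2 in one respect: (4-fluorophenyl)carbonyl in place of cyano on an aromatic carbon. For the measured compounds named here, nothing among the measured compounds speaks to what such an exchange does to the readout. Compound 3 is therefore expected at an estimated 4 ug/mL, with a range from 1.5 ug/mL to 11 ug/mL. The step this estimate implies, a 1.2-fold higher number from compound 2 to compound 3 (0.08 log units; within the scatter), is expected to be none beyond the scatter.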

Compound 3, half-maximal inhibitory concentration: 7.8 ug/mL
Estimate against measurement, compound 3: 2.0-fold (0.29 log units) below, within the range that was stated.
By their numbers in this assay, from the lowest: compounds 2 and 1 (each within the scatter of the next); then compound 3.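

Among the compounds shown here, the exchange of cyano for (4-fluorophenyl)carbonyl on this aromatic carbon gives the first step beyond the scatter in this assay, a 2.4-fold higher number from compound 2 to compound 3 (0.37 log units; beyond the scatter), so this position does respond to the group it carries. The response is modest, although the entering group is far larger and brings a six-membered aromatic ring, while the two groups match in their counts of hydrogen-bond donors and acceptors. No measurement on hand accounts for the rise.

With one exchange at this position, the compounds shown cannot separate the part played by the carbonyl, the aromatic ring and the fluorine. They also leave open how a plain phenylcarbonyl, a carboxylic acid or an amine on this carbon would read out in this assay.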